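The source may report more compounds than this note shows. Statements on the series, on what has been measured and on what is new or still open speak of the compounds shown alone.

Measured so far:
compound 1 `N#Cc1ccc(CS(=O)(=O)NC(=O)C2CCN(c3nc4c(cc3C#N)C(=O)OC4)CC2)cc1` — a functional assay (Platelet, plasma) for inhibition, with Homo sapiens as the target (on this read-out lower numbers stand for stronger inhibition and higher numbers for weaker inhibition), 8900 nM
compound 2 `N#Cc1cc2c(nc1N1CCC(C(=O)NS(=O)(=O)Cc3ccc(F)cc3F)CC1)COC2=O` — this assay 5200 nM

Within the data shown here, compound 2 holds the lowest of the two numbers; its only neighbour is compound 1, and the gap a 1.7-fold lower number from compound 1 to compound 2 (0.23 log units; within the scatter) lies within the scatter. Compound 3 `N#Cc1cc2c(nc1N1CCC(C(=O)NS(=O)(=O)C3(c4ccccc4)CC3)CC1)COC2=O` differs from compound 2 at one place: 1-phenylcyclopropyl in place of 2,4-difluorobenzyl on a sulfonyl sulfur. Among the measured compounds shown here, the single step that bears on it, a 1.7-fold lower number from compound 1 to compound 2 (0.23 log units; within the scatter), swapped one group on this same sulfonyl sulfur and stayed within the scatter. For the measured compounds named here, no other step touches this position, so the step of a 1.0-fold lower number from compound 2 to compound 3 (0.02 log units; within the scatter) is expected to stay within the scatter as well. Compound 3 is estimated at 5000 nM, between 1500 nM and 16000 nM.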

Compound 3, half-maximal inhibitory concentration: 4100 nM
The estimate for compound 3 lay 1.2-fold (0.09 log units) above the measured number, and the stated range covers the measured number.
By their numbers in this assay, from the lowest: compounds 3, 2 and 1 (each within the scatter of the next, the first and the last beyond it).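

Among these compounds, on the sulfonyl sulfur, the change to 1-phenylcyclopropyl gives a 2.2-fold lower number from compound 1 to compound 3 (0.34 log units; beyond the scatter) in this assay, the first step at this position to pass the scatter, though only modestly. By contrast, a 1.3-fold lower number from compound 2 to compound 3 (0.10 log units; within the scatter), so 1-phenylcyclopropyl and 2,4-difluorobenzyl cannot be told apart here, even though a three-membered ring enters and both fluorines leave. Still open, from the compounds shown here alone, is whether an amine, a carboxylic acid or a longer chain on this sulfur would move the number further from compound 3. Nothing available explains these differences.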